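Trimming a Methyl from the Linker of Compound 2

The compounds below may be only part of what the source reports. "The series", "measured", "known", "first", "only" and "open" are said of these compounds alone.

Compound 2 `CC1=C(CCC(=O)OCC(C)COc2no[n+]([O-])c2S(=O)(=O)c2ccccc2)C(=O)c2c(O)cccc2C1=O` and compound 1 `CC1=C(C(C)CC(=O)OCCCOc2no[n+]([O-])c2S(=O)(=O)c2ccccc2)C(=O)c2c(O)cccc2C1=O` share one core and differ only in their linking chains. In a functional assay on HepG2 cells (Homo sapiens) for inhibition, read by MTT assay, with a stated time of 72 h (a lower number here means a stronger inhibitor, a higher number a weaker inhibitor), compound 2 gives 6690 nM, and compound 1 gives 4320 nM, a number within the scatter of repeated measurements of compound 2. Compound 3 `CC1=C(CCC(=O)OCCCOc2no[n+]([O-])c2S(=O)(=O)c2ccccc2)C(=O)c2c(O)cccc2C1=O` has not yet been measured. It differs from compound 2 by hydrogen in place of methyl on a saturated chain carbon bound to two saturated chain carbons. Within the data shown here, no measured pair shows this kind of change, so the expected step is small and within the scatter: a 1.2-fold lower number from compound 2 to compound 3 (0.06 log units; within the scatter). In this assay compound 3 is expected to give 5800 nM, with a range from 2700 nM to 12500 nM.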

Compound 3, half-maximal inhibitory concentration: 6790 nM
The estimate for compound 3 lay 1.2-fold (0.07 log units) below the measured number, and the stated range covers the measured number.
By their numbers in this assay, from the lowest: compounds 1, 2 and 3 (each within the scatter of the next).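

Taking the methyl off the saturated chain carbon bound to two saturated chain carbons leaves this assay within the scatter, with a 1.0-fold higher number from compound 2 to compound 3 (0.01 log units; within the scatter). The same holds for the methyl on the saturated chain carbon bound to a double-bonded ring carbon and a saturated chain carbon, with a 1.6-fold higher number from compound 1 to compound 3 (0.20 log units; within the scatter). Neither methyl is thus needed to keep the number in this range, and no supporting data bear on the result.

As far as these compounds go, whether a larger group at either carbon, such as ethyl or an amine, would shift the number remains open. So does the effect of a longer chain.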